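The source may hold more compounds than are shown below. What is called first, only, known or untested is meant among the compounds shown, and "the series" means these compounds.

Compound 1 `CSCC(=O)N1CCN(c2nc(=O)c3cc(C(F)(F)F)cc([N+](=O)[O-])c3s2)CC1`: 15.2 ug/mL
Compound 2 `O=C(c1cccc(F)c1)N1CCN(c2nc(=O)c3cc(C(F)(F)F)cc([N+](=O)[O-])c3s2)CC1`: 0.2 ug/mL
Compound 3 `O=C(C1CCCC1)N1CCN(c2nc(=O)c3cc(C(F)(F)F)cc([N+](=O)[O-])c3s2)CC1`: 5.34 ug/mL

In a physicochemical assay for solubility, read by HPLC (on this read-out lower numbers stand for lower solubility and higher numbers for higher solubility), compound 3 gives 5.34 ug/mL, the second highest of the three numbers. The nearest number belongs to compound 1, with the step of a 2.8-fold lower number from compound 1 to compound 3 (0.45 log units; beyond the scatter); the furthest belongs to compound 2, with the step of a 27-fold higher number from compound 2 to compound 3 (1.43 log units; beyond the scatter). Compound 4 `CC(C)CC(=O)N1CCN(c2nc(=O)c3cc(C(F)(F)F)cc([N+](=O)[O-])c3s2)CC1` differs from compound 3 by isobutyl in place of cyclopentyl on a carbonyl carbon. Both measured steps alter the same carbonyl carbon, one by a modest amount and one by a large amount, but neither exchanges two saturated hydrocarbon groups of nearly equal size, so no direct guide exists. The step from compound 3 is expected to stay small, around a 1.3-fold higher number from compound 3 to compound 4 (0.12 log units; within the scatter). For compound 4 the estimate in this assay is 7 ug/mL, within a range from 2.5 ug/mL to 20 ug/mL.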

Compound 4, solubility: 66.3 ug/mL
The estimate for compound 4 lay 9.5-fold (0.98 log units) below the measured number, outside the stated range (above it).
By their numbers in this assay, from the lowest: compound 2; then compound 3; then compound 1; then compound 4.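

In this assay, isobutyl in place of cyclopentyl on the carbonyl carbon gives a 12-fold higher number from compound 3 to compound 4 (1.09 log units; beyond the scatter) as a large step, so these two saturated hydrocarbon groups are not interchangeable at this position. The position now spans a 330-fold higher number from compound 2 to compound 4 (2.52 log units; beyond the scatter) as its widest step, and a 4.4-fold higher number from compound 1 to compound 4 (0.64 log units; beyond the scatter) puts compound 4 highest of the four. No measurement at hand accounts for these steps. Still open, as far as these compounds go, is whether the higher number follows from the missing ring or from the branching, and whether a straight butyl chain, a cyclobutyl ring or a chain bearing an amine would stand nearer compound 3 or compound 4.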